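This account rests on a few compounds, and the source may have more. Where it says the series, first, only, none or still open, it means among the compounds named here.

In an ADME assay on Vero cells (Chlorocebus sabaeus) for cytotoxicity, with a stated time of 3 days (a lower number here means a stronger inhibitor, a higher number a weaker inhibitor), compound 2 `CCOC(=O)Nc1cc(N)c2[nH]c(-c3ccc(Br)cc3)nc2c1` gives > 200 ug/mL, a value that is a limit of the assay rather than a number. Compound 1 `CCN(CC)c1cc2[nH]c(-c3ccc(F)cc3)nc2cc1NC(=O)C1CCC1` likewise gives > 200 ug/mL, again a limit. Compound 3 `CCOC(=O)Nc1cc(N)c2[nH]c(-c3cc(C)cc(C)c3)nc2c1` gives > 200 ug/mL, also a limit. The step from compound 2 to compound 3 is therefore a step that the two limits leave unreadable from compound 2 to compound 3, and all that is known is the limit of > 200 ug/mL in this assay, at which 3 of the 3 values shown sit. Compound 4 `CCOC(=O)Nc1cc(NC(=O)c2ccccc2OC)c2[nH]c(-c3ccc(Br)cc3)nc2c1` differs from compound 2 in this way: (2-methoxyphenyl)carbonyl in place of hydrogen on a nitrogen on an aromatic ring. For the measured compounds named here, no measured step shows what this change does in this assay, and the three limits leave no direction to read. Compound 4 is therefore expected to give about 200 ug/mL, within 80 ug/mL to 400 ug/mL. The step from compound 2 to compound 4 is expected to be a number no higher from compound 2 to compound 4 (the limit leaves the size open).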

Compound 4, half-maximal inhibitory concentration: > 200 ug/mL
Compound 4: only a limit was reported; the forecaster's own chance of this, stated with the estimate: 65%; the middle value sits exactly at the limit.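

For the compounds shown here, the results for compound 2 and compound 4 in this assay are both limits of the assay, and no step between them can be read. The compounds shown leave open whether (2-methoxyphenyl)carbonyl in place of hydrogen changes cytotoxicity at all.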